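Swapping the tetrahydroisoquinoline for a benzimidazole

A few compounds are considered here, and "the series" means these few. Any claim that something is new, unique, unknown or untested is made for them only; others in the source may bear on it.

Measured compounds:
- compound 1 `c1ccc2c(c1)CN[C@@H](CN(CC1CCNCC1)[C@H]1CCCc3cccnc31)C2`: 65 nM
- compound 2 `c1ccc2c(c1)CN[C@H](CN(CCCN1CCNCC1)[C@H]1CCCc3cccnc31)C2`: 1150 nM
- compound 3 `c1ccc2c(c1)CN[C@@H](CN(CCC1CCNCC1)[C@H]1CCCc3cccnc31)C2`: 150 nM

In a functional assay on CCRF-CEM cells for antagonist activity at C-X-C chemokine receptor type 4 (Homo sapiens), read by calcium flux, with stated times of 25 min and 90 s (a higher number here means a weaker inhibitor, a lower number a stronger inhibitor), compound 2 gives the highest number of the three, so it is the weakest inhibitor shown; compound 3 gives 150 nM and compound 1 gives 65 nM. Among the compounds with values here, the one step measured here is a 2.3-fold higher number from compound 1 to compound 3 (0.36 log units; beyond the scatter), and it concerns the piperidine side of the molecule, not the part changed below.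

Compound 4 `c1cnc2c(c1)CCC[C@@H]2N(CCCN1CCNCC1)Cc1nc2ccccc2[nH]1` is compound 2 with a different group on the other arm: 1H-benzimidazol-2-yl in place of 1,2,3,4-tetrahydroisoquinolin-3-yl on a saturated chain carbon bound to an amine nitrogen. No measured step touches this position, so the numbers shown give no direction for the change. The only sound starting point is the value of compound 2, with a wide allowance either way. The expected step of a 1.3-fold lower number from compound 2 to compound 4 (0.11 log units; within the scatter) is therefore set as no change beyond the scatter, and compound 4 is estimated at 900 nM, within a range from 150 nM to 5000 nM.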

Compound 4, half-maximal inhibitory concentration: 45 nM
Compound 4: the middle estimate sits 20-fold (1.30 log units) above what was measured; the whole stated range lies above it.
By their numbers in this assay, from the lowest: compounds 4 and 1 (each within the scatter of the next); then compound 3; then compound 2.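

In this assay, the group on the saturated chain carbon bound to an amine nitrogen proves to have a strong hold on the result: putting 1H-benzimidazol-2-yl in place of 1,2,3,4-tetrahydroisoquinolin-3-yl gives a 26-fold lower number from compound 2 to compound 4 (1.41 log units; beyond the scatter). The earlier compounds shown here all carry 1,2,3,4-tetrahydroisoquinolin-3-yl, so they could not show this. The change also shows that a low number here does not need this group's defined stereocentre or its six-membered non-aromatic ring, since the entering group has neither, and no measurement given here explains the size of the step.

Going by these compounds, it remains open whether the same replacement would give a similar step with the side chains of compound 1 and compound 3. Whether the second ring nitrogen matters is also unsettled, and a 1H-indol-2-yl group in the same place would test that.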